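Swapping an ortho-bromophenyl for a para-nitrophenyl

This account rests on a few compounds, and the source may have more. Where it says the series, first, only, none or still open, it means among the compounds named here.

Compound 1 `COc1cc2c(Oc3ccc(NC(=O)c4nn(-c5cccc(F)c5)c(=O)c5ccccc45)cc3F)ccnc2cc1OCCCN1CCCC1`: 190 nM
Compound 2 `COc1cc2c(Oc3ccc(NC(=O)c4nn(-c5ccc(Br)cc5)c(=O)c5ccccc45)cc3F)ccnc2cc1OCCCN1CCCC1`: 180 nM
Compound 3 `COc1cc2c(Oc3ccc(NC(=O)c4nn(-c5ccccc5Br)c(=O)c5ccccc45)cc3F)ccnc2cc1OCCCN1CCCC1`: 320 nM

All three were tested in a functional assay on NCI-H460 cells (Homo sapiens) for cytotoxicity, read by MTT assay, with a stated time of 72 h (a higher number here means a weaker inhibitor, a lower number a stronger inhibitor), and compound 3 gives the highest of the three numbers, though its steps to compound 1 and compound 2 both stay within the scatter. Compound 4 `COc1cc2c(Oc3ccc(NC(=O)c4nn(-c5ccc([N+](=O)[O-])cc5)c(=O)c5ccccc45)cc3F)ccnc2cc1OCCCN1CCCC1` has not yet been measured; relative to compound 3 the change is 4-nitrophenyl in place of 2-bromophenyl on an aromatic nitrogen.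

The closest guide is a 1.8-fold higher number from compound 2 to compound 3 (0.25 log units; within the scatter), which moves a bromine from the para to the ortho position of that phenyl ring without a change beyond the scatter; a 1.7-fold higher number from compound 1 to compound 3 (0.23 log units; within the scatter) is similar in size. Nothing measured here separates a nitro group from a bromine. Compound 4 is therefore expected to land near the other para-substituted analogue, with a step of a 1.4-fold lower number from compound 3 to compound 4 (0.14 log units; within the scatter), giving an estimate of 230 nM within the range 100 nM to 550 nM.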

Compound 4, half-maximal inhibitory concentration: 1240 nM
Beside the measured number, compound 4's estimate is 5.4-fold (0.73 log units) below it; the whole stated range lies below it.
By their numbers in this assay, from the lowest: compounds 2, 1 and 3 (each within the scatter of the next); then compound 4.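

For the compounds shown here, the group on this ring nitrogen turns out not to be interchangeable in this assay: the bromo and fluoro analogues stayed within the scatter of one another, yet the single swap of nitro for bromo gives a 6.9-fold higher number from compound 2 to compound 4 (0.84 log units; beyond the scatter) on the same phenyl ring. The other two comparisons point the same way, with a 3.9-fold higher number from compound 3 to compound 4 (0.59 log units; beyond the scatter) and a 6.5-fold higher number from compound 1 to compound 4 (0.81 log units; beyond the scatter) setting compound 4 apart from all three halogen-bearing compounds. No evidence here accounts for this difference. Still open, going by these compounds, is whether the higher number is particular to the nitro group or would also appear with a 4-aminophenyl or a 4-carboxyphenyl in its place.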